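Removing the bromine from a non-toxic indole hydrazone

This account rests on a few compounds, and the source may have more. Where it says the series, first, only, none or still open, it means among the compounds named here.

The study concerns three close relatives sharing one core. Compound 1 `Cn1cc(/C=N\NC(=O)c2cn(C)c3ccc(Br)cc23)c2ccccc21` was tested in an ADME assay on HEK293 cells (Homo sapiens) for cytotoxicity, read by MTT assay, with a stated time of 4 h (a higher number here means a weaker inhibitor, a lower number a stronger inhibitor), where compound 1 returns only a limit, > 200000 nM, and no single number. Its partner compound 2 `Cn1cc(C(=O)N/N=C\c2c[nH]c3ccccc23)c2cc(Br)ccc21` is recorded in this assay simply as "not toxic" (no number reported), again without a figure. So compound 1 sits at the limit shared by one of the two entries, (the limit of > 200000 nM in this assay, at which 1 of the 2 values shown sits), and no measured step between the two compounds can be drawn.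

Compound 3 `Cn1cc(/C=N\NC(=O)c2cn(C)c3ccccc23)c2ccccc21` differs from compound 1 in one place, (hydrogen in place of bromo on an aromatic carbon). Among the measured compounds shown here, with no measured step to guide it, the expected change in this assay is none beyond the scatter, given that compound 1 already gives > 200000 nM as a limit. Compound 3 is therefore estimated at 200000 nM, within 80000 nM to 500000 nM, which means an expected step of a number no higher from compound 1 to compound 3 (the limit leaves the size open).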

Compound 3, half-maximal inhibitory concentration: "not toxic" (no number reported)
The entry for compound 3 holds no number, and the estimate cannot be compared.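

In this assay, among the compounds shown here, compound 1 holds only a limit and compound 3 is entered as "not toxic" without a number, so no step between them can be read. The compounds shown leave open whether hydrogen in place of bromo changes cytotoxicity at all.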